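The compounds below may be only part of what the source reports. "The series", "measured", "known", "first", "only" and "open" are said of these compounds alone.

The measured compounds:
Compound 1, `COc1cc2nc(N3CCN(S(=O)(=O)c4ccc([N+](=O)[O-])cc4)CC3)nc(N)c2cc1OC`, gives 36000 nM in a functional assay on PC-3 cells (Homo sapiens) for inhibition; on this read-out lower numbers stand for stronger inhibition and higher numbers for weaker inhibition.
Compound 2, `COc1ccc(S(=O)(=O)N2CCN(c3nc(N)c4cc(OC)c(OC)cc4n3)CC2)cc1`, gives 39000 nM in this assay.
Compound 3, `COc1cc2nc(N3CCN(S(=O)(=O)c4ccc5ccccc5c4)CC3)nc(N)c2cc1OC`, gives 15000 nM in this assay.

Compound 3 has the lowest number of the three: the drops are a 2.4-fold lower number from compound 1 to compound 3 (0.38 log units; beyond the scatter) and a 2.6-fold lower number from compound 2 to compound 3 (0.41 log units; beyond the scatter), both modest steps beyond the scatter, while a 1.1-fold higher number from compound 1 to compound 2 (0.03 log units; within the scatter) stays within it. Compound 4, `COc1cc2nc(N3CCN(S(=O)(=O)c4ccc(-c5ccccc5)cc4)CC3)nc(N)c2cc1OC`, differs from compound 3 by 4-phenylphenyl in place of naphthalen-2-yl on a sulfonyl sulfur. For the measured compounds named here, no measured step sets these two groups against each other; the only guidance is that a two-ring group in place of a substituted phenyl gave those modest gains, and compound 4 keeps a two-ring group. The expectation in this assay is therefore a step of a 1.2-fold lower number from compound 3 to compound 4 (0.06 log units; within the scatter), most likely within the scatter. Compound 4 is thus estimated at 13000 nM, with a range of 5000 nM to 35000 nM.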

Compound 4, half-maximal inhibitory concentration: 4200 nM
The estimate for compound 4 lay 3.1-fold (0.49 log units) above the measured number; the whole stated range lies above it.
By their numbers in this assay, from the lowest: compound 4; then compound 3; then compounds 1 and 2 (each within the scatter of the next).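

In this assay there is a 3.6-fold lower number from compound 3 to compound 4 (0.55 log units; beyond the scatter) when 4-phenylphenyl replaces naphthalen-2-yl on the sulfonyl sulfur, so two groups with the same count of aromatic rings are not interchangeable at this position. Phenyl in place of methoxy gives a 9.3-fold lower number from compound 2 to compound 4 (0.97 log units; beyond the scatter) and phenyl in place of nitro gives an 8.6-fold lower number from compound 1 to compound 4 (0.93 log units; beyond the scatter) on the same aromatic carbon. No measured evidence here accounts for these differences. Still open, on these data alone, is whether an amine or a carboxylic acid on that aromatic carbon, in place of phenyl, would keep the number this low.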